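This account rests on a few compounds, and the source may have more. Where it says the series, first, only, none or still open, it means among the compounds named here.

Measured compounds:
- compound 1, `CN(Cc1ccc(C(=O)O)cc1)c1ccc(OCc2c(-c3c(Cl)cccc3Cl)noc2C2CC2)nc1C(F)(F)F`: 12 nM
- compound 2, `CC(Nc1ccc(C(=O)O)cc1)c1ccc(OCc2c(-c3c(Cl)cccc3Cl)noc2C2CC2)nc1C(F)(F)F`: 101 nM

In an assay on isolated protein for agonist activity at Bile acid receptor (Homo sapiens), read by FRET (on this read-out higher numbers stand for an effect only at larger amounts of compound and lower numbers for an effect already at smaller amounts), compound 1 gives 12 nM, and compound 2 gives 101 nM. Among the compounds with values here, compound 2 thus carries the higher of the two numbers; the only measured step that reaches it, an 8.4-fold higher number from compound 1 to compound 2 (0.93 log units; beyond the scatter), shows that exchanging the linker between the shared core and the carboxyphenyl group already shifts the read-out.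

Compound 3, `O=C(O)c1ccccc1OCc1ccc(OCc2c(-c3c(Cl)cccc3Cl)noc2C2CC2)nc1C(F)(F)F`, has not been measured. It differs from compound 2 in that ((2-carboxyphenoxy)methyl in place of 1-((4-carboxyphenyl)amino)ethyl on an aromatic carbon). Within the data shown here, this change once more alters the linker, and in addition moves the acid to a different position on its ring, so it goes further than the one measured step. Among the measured compounds shown here, that step, an 8.4-fold higher number from compound 1 to compound 2 (0.93 log units; beyond the scatter), is the only guide, and it was modest in size. On this basis compound 3 is expected to give a further, modest increase, a 3.0-fold higher number from compound 2 to compound 3 (0.47 log units; beyond the scatter), with wide uncertainty in both directions. The estimate for compound 3 in this assay is 300 nM, with a range from 50 nM to 3000 nM.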

Compound 3, half-maximal effective concentration: 434 nM
Compound 3: middle estimate off by 1.4-fold (0.16 log units), on the low side; measured number inside the range.
By their numbers in this assay, from the lowest: compound 1; then compound 2; then compound 3.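

In this assay, placing (2-carboxyphenoxy)methyl instead of 1-((4-carboxyphenyl)amino)ethyl on the aromatic carbon ortho to the trifluoromethyl group gives a 4.3-fold higher number from compound 2 to compound 3 (0.63 log units; beyond the scatter) and moves the read-out in the same direction as the first measured step, this time with a group that contains no nitrogen. Set against the (4-carboxybenzyl)(methyl)amino group, the same (2-carboxyphenoxy)methyl group gives a 36-fold higher number from compound 1 to compound 3 (1.56 log units; beyond the scatter) and is the only large step among the three compounds, so changing this one substituent while the rest of the molecule stays the same can shift the number much further than the earlier pair showed. No supporting data on hand bear on why these groups differ.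

In compound 3 the linker and the place of the acid on its ring change together, and the compounds shown do not separate the two contributions. Also open, from the compounds shown here alone, is how the read-out at this position would respond to an amide in the linker, or to a tetrazole in place of the carboxylic acid.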